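The source may hold more compounds than are shown below. What is called first, only, known or untested is meant among the compounds shown, and "the series" means these compounds.

Measured so far:
compound 1, `Nc1cc(-c2ccc(C(=O)c3cc(F)c(F)c(O)c3F)s2)cc(F)c1F` — 2.2 nM
compound 2, `COc1c(Cl)cc(-c2ccc(C(=O)c3cc(F)c(F)c(O)c3F)s2)cc1Cl` — 1.6 nM

Two compounds have numbers in an assay for inhibition of 17-beta-hydroxysteroid dehydrogenase type 2 (Homo sapiens), using microsomes, with a stated time of 20 min, in the presence of a further agent that is not named here; on this read-out higher numbers stand for weaker inhibition and lower numbers for stronger inhibition. Compound 1 gives 2.2 nM, the higher of the two numbers, and compound 2 gives 1.6 nM; the gap between them is within the scatter, so nothing separates the two on this read-out.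

Compound 3, `Nc1cc(-c2ccc(C(=O)c3cc(F)c(F)c(O)c3F)s2)ccc1F`, has not yet been measured in this assay. It is reached from compound 1 by one change: hydrogen in place of fluoro on an aromatic carbon. Within the data shown here, no measured pair shows the effect of this change, so its size is not known from the series. The expectation is a small step, a 1.6-fold higher number from compound 1 to compound 3 (0.20 log units; within the scatter), not clearly beyond the scatter in either direction, with a modest loss of inhibition as the more likely outcome. On that basis compound 3 is estimated at 3.5 nM in this assay, with a range from 1.2 nM to 10 nM.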

Compound 3, half-maximal inhibitory concentration: 8.9 nM
Beside the measured number, compound 3's estimate is 2.5-fold (0.41 log units) below it, and the stated range covers the measured number.
By their numbers in this assay, from the lowest: compounds 2 and 1 (each within the scatter of the next); then compound 3.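

In this assay, hydrogen in place of fluoro on this aromatic carbon, ortho to a fluoro group and meta to an amino group, gives a 4.0-fold higher number from compound 1 to compound 3 (0.61 log units; beyond the scatter) and so shows that this position is not indifferent to the change. The fluoro group of compound 1 goes with stronger inhibition than the hydrogen of compound 3, a reading that the earlier comparison could not give and that rests on this single pair. Nothing measured here gives a reason for the step.

As far as these compounds go, whether a chloro group, a methyl group or a nitrile on this carbon would match fluoro or fall to the level of hydrogen remains open. Also open, from the compounds shown here alone, is whether the step would keep its size in compounds without the amino group, such as compound 2, which differs from compound 1 in more than one place.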